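The compounds below may be only part of what the source reports. "The series", "measured", "known", "first", "only" and "open" are said of these compounds alone.

In an assay on cells (Oocyte) for inhibition of pannexin-1 (Mus musculus), read by voltage clamp, tested at 50 uM, in the presence of a further agent that is not named here (a higher number here means more inhibition at the concentration tested (going by the name of the read-out), a lower number less inhibition), compound 1, whose structure is `O=C(O)c1ccc(Cn2c(C(=O)O)cc3cc(S(=O)(=O)N(Cc4ccccc4)Cc4ccccc4)ccc32)cc1`, gives 100%. Compound 2, with the structure `O=C(O)c1cc2cc(S(=O)(=O)N(Cc3ccccc3)Cc3ccccc3)ccc2n1Cc1ccccc1`, gives 41% in this assay. The two differ by hydrogen in place of carboxy on an aromatic carbon, and this single change produced a number 59 percentage points lower from compound 1 to compound 2 (beyond the scatter).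

Compound 3, with the structure `NS(=O)(=O)c1ccc2c(c1)cc(C(=O)O)n2Cc1ccc(C(=O)O)cc1`, gives 61.7% in this assay. It thereby stands between the other two measured compounds, with both gaps beyond the scatter. The difference between the core of compound 3 and the core of compound 1 is not broken down here.

Compound 4, whose structure is `NS(=O)(=O)c1ccc2c(c1)cc(C(=O)O)n2Cc1ccccc1`, has not yet been measured. It differs from compound 3 by hydrogen in place of carboxy on an aromatic carbon, which is the same change as that between compound 1 and compound 2, made at the same place on the same ring. From compound 1 to compound 2 that change cost a large share of the inhibition, and compound 3 starts from a lower value than compound 1 did. Compound 4 is therefore expected to show a step of roughly a number 46.7 percentage points lower from compound 3 to compound 4 (beyond the scatter), smaller in absolute terms than the earlier one. Compound 4 is estimated to give about 15% in this assay, with a plausible range from 0% to 40%. This rests on the measured values of compound 1, compound 2 and compound 3 alone, and the actual measurement will show whether it holds.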

Compound 4, a percentage reported as inhibition, at one concentration (the size of the read-out at that concentration, not a potency): 29.3%
Compound 4: the middle estimate sits 14.3 percentage points below what was measured; the range from low to high includes it.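

In this assay the removal of the carboxy group again lowers the number, a number 32.4 percentage points lower from compound 3 to compound 4 (beyond the scatter), and the direction of this change therefore holds on both cores shown. Its size does not carry over unchanged from one core to the other: the same change on two cores in this assay, a number 59 percentage points lower (beyond the scatter) from compound 1 to compound 2 and a number 32.4 percentage points lower (beyond the scatter) from compound 3 to compound 4, 26.6 percentage points apart, beyond the scatter of two such steps These two pairs show only that the size of the step depends on the core it is made on; they do not show which part of the cores sets that size or how large the step would be on a further core, and, since each number is the size of the read-out at one tested concentration, they say nothing about potency.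

What the compounds shown leave open is whether an acid is needed at this place at all, since a methyl ester, a primary amide or a tetrazole in place of the carboxy group would separate the effect of a carboxylic acid from that of any other group there. Also open, on these data alone, is how the step behaves on cores whose sulfonamide nitrogen carries something other than two hydrogens or two benzyl groups, such as a single benzyl group or a short alkyl chain.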